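The source may hold more compounds than are shown below. What is called first, only, known or untested is meant among the compounds shown, and "the series" means these compounds.

Three compounds of this set have numbers in an ADME assay on liver (Mesocricetus auratus) for metabolic stability, using microsomes; on this read-out higher numbers stand for fast clearance and lower numbers for slow clearance. Compound 1 `O=C(Nc1cc(-c2ccccn2)n[nH]1)N1CCC(Oc2ccccn2)CC1` gives 67.3 mL.min-1.g-1, compound 2 `N#Cc1ccc(OC2CCN(C(=O)Nc3cc(-c4ccccn4)n[nH]3)CC2)cc1` gives 30.8 mL.min-1.g-1, and compound 3 `O=C(Nc1cc(-c2ccccn2)n[nH]1)N1CCC(c2ccccc2)CC1` gives 216 mL.min-1.g-1, the highest of the three, its steps to both others lying beyond the scatter. Compound 4 `N#Cc1ccc(C2CCN(C(=O)Nc3cc(-c4ccccn4)n[nH]3)CC2)cc1` differs from compound 3 by cyano in place of hydrogen on an aromatic carbon. Going by the values given here, no measured step repeats this exact change, but two steps bear on it: the step of a 2.2-fold lower number from compound 1 to compound 2 (0.34 log units; beyond the scatter) and the step of a 7.0-fold higher number from compound 2 to compound 3 (0.85 log units; beyond the scatter), both pointing toward lower numbers when a cyano group is present on the ring. Compound 4 is therefore expected to give a modestly lower number, estimated at 100 mL.min-1.g-1 with a range from 50 mL.min-1.g-1 to 200 mL.min-1.g-1, a step of a 2.2-fold lower number from compound 3 to compound 4 (0.33 log units; beyond the scatter).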

Compound 4, intrinsic clearance in microsomes: 80.8 mL.min-1.g-1
Beside the measured number, compound 4's estimate is 1.2-fold (0.09 log units) above it; the range from low to high includes it.
By their numbers in this assay, from the lowest: compound 2; then compounds 1 and 4 (each within the scatter of the next); then compound 3.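

In this assay the change from phenyl to 4-cyanophenyl gives a 2.7-fold lower number from compound 3 to compound 4 (0.43 log units; beyond the scatter) on a ring attached with no oxygen link, a direct reading of the nitrile at this place. With the nitrile kept, 4-cyanophenyl in place of 4-cyanophenoxy still gives a 2.6-fold higher number from compound 2 to compound 4 (0.42 log units; beyond the scatter) as a step of its own. Against the (pyridin-2-yl)oxy group, a 1.2-fold higher number from compound 1 to compound 4 (0.08 log units; within the scatter) leaves no order between the two compounds.

Nothing given here accounts for these steps. On these data alone, whether an amine or a carboxylic acid at the same ring place would also give a lower number remains open.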